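The compounds below may be only part of what the source reports. "The series", "measured", "known", "first", "only" and "open" are said of these compounds alone.

Measured so far:
compound 1 `Cc1nc(O[C@H]2CC[C@H](OC3CCN(C(=O)OC(C)(C)C)CC3)CC2)ccc1C(=O)N(C)C` — 111%
compound 2 `CC(C)(C)OC(=O)N1CCC(O[C@H]2CC[C@H](Oc3cnc(C#N)cn3)CC2)CC1` — 100%
compound 3 `C[C@@H](CF)OC(=O)N1CCC(O[C@H]2CC[C@H](Oc3cnc(S(C)(=O)=O)cn3)CC2)CC1` — 123%

In a functional assay on isolated protein for agonist activity at Glucose-dependent insulinotropic receptor (Rattus norvegicus), read by HTRF and cAMP accumulation (a higher number here means a larger maximal response, a lower number a smaller maximal response), all three measured compounds reach a response at or above that of the reference. Compound 3 stands highest of the three numbers. Its nearest neighbour is compound 1, whose value sits lower by a margin beyond the usual scatter; furthest away is compound 2, whose value sits lower still, also beyond the scatter. Among the compounds with values here, no pair among the measured compounds differs in one place only, so no single-change step can be read from these numbers.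

Compound 4 `CS(=O)(=O)c1cnc(O[C@H]2CC[C@H](OC3CCN(CC4(C(F)(F)F)CC4)CC3)CC2)cn1` keeps the core of compound 3 and differs from it in one place:
a group of 8 heavy atoms (5 carbon, 3 fluorine; one three-membered non-aromatic ring of carbon only) in place of a group of 7 heavy atoms (4 carbon, 2 oxygen, 1 fluorine; no ring), on an amine nitrogen in a ring

Within the data shown here, no measured step describes this kind of change. The three measured values show that the shared core gives a full or more than full maximal response with three different groups on the amine nitrogen in the ring, so compound 4 is expected to remain in that range. The step from compound 3 is expected to be small, a number 13 percentage points lower from compound 3 to compound 4 (beyond the scatter), most likely downward but not clearly beyond the scatter. For compound 4 the maximal response in this assay is estimated at 110%, with a range from 90% to 130%.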

Compound 4, largest response reached (Emax), in percent of the reference or control that the assay uses: 124%
Beside the measured number, compound 4's estimate is 14 percentage points below it, and the stated range covers the measured number.
By their numbers in this assay, from the lowest: compound 2; then compound 1; then compounds 3 and 4 (each within the scatter of the next).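

In this assay, the change on the amine nitrogen in a ring gives a number 1 percentage points higher from compound 3 to compound 4 (within the scatter), so in this pair the maximal response is unchanged when a group with 2 hydrogen-bond acceptors and 1 defined stereocentre gives way to (1-(trifluoromethyl)cyclopropyl)methyl, which has 0 hydrogen-bond acceptors and a three-membered ring of carbon only. Compounds 1, 2 and 3 all carry a carbonyl in the group on this nitrogen and compound 4 carries none, so with this core and this aromatic end group, a carbonyl there is not required for a full maximal response. No measurement at hand bears on why these two different groups give matching responses.

Still open, as far as these compounds go, is whether the response also holds with a carboxylic acid, a longer alkyl chain or a plain hydrogen on this nitrogen. Also open, from the compounds shown here alone, is whether (1-(trifluoromethyl)cyclopropyl)methyl gives the same result with the nitrile-bearing end of compound 2 or the amide-bearing end of compound 1, as the maximal response alone does not show how the group behaves on those other ends.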